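A few compounds are considered here, and "the series" means these few. Any claim that something is new, unique, unknown or untested is made for them only; others in the source may bear on it.

Compound 2 `CCNCc1ccc(Cl)c(-c2ccccc2OC)c1` gives 1400 nM in an assay on isolated protein for binding affinity to 5-hydroxytryptamine receptor 6 (Homo sapiens) (a lower number here means a stronger inhibitor, a higher number a weaker inhibitor), the highest number among the three measured compounds. Compound 1 `COc1ccccc1-c1cc(CN(C)C)ccc1Cl` gives 440 nM and compound 3 `CCCCNCc1ccc(Cl)c(-c2ccccc2OC)c1` gives 240 nM. The amine is the only site varied so far: a 3.2-fold higher number from compound 1 to compound 2 (0.50 log units; beyond the scatter), while a 5.8-fold lower number from compound 2 to compound 3 (0.77 log units; beyond the scatter), and the pair 1 and 3 stays within the scatter. Compound 4 `COc1ccccc1-c1cc(C2CCNC2)ccc1Cl` carries pyrrolidin-3-yl in place of (ethylamino)methyl on an aromatic carbon, on an aromatic carbon meta to a group of 8 heavy atoms and para to a chloro group. Within the data shown here, no measured step covers ring closure at this site, so the expectation leans on the amine steps alone, which suggest a modest move downward. Compound 4 is estimated at 450 nM (120 nM to 1700 nM), a step of a 3.1-fold lower number from compound 2 to compound 4 (0.49 log units; beyond the scatter).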

Compound 4, inhibition constant: 400 nM
For compound 4 the middle estimate is 1.1-fold (0.05 log units) above the measured one; the range from low to high includes it.
By their numbers in this assay, from the lowest: compounds 3, 4 and 1 (each within the scatter of the next); then compound 2.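

A ring amine can stand on this aromatic carbon in place of the open-chain amines: in this assay pyrrolidin-3-yl shows a 3.5-fold lower number from compound 2 to compound 4 (0.54 log units; beyond the scatter) and leaves a 1.1-fold lower number from compound 1 to compound 4 (0.04 log units; within the scatter) and a 1.7-fold higher number from compound 3 to compound 4 (0.22 log units; within the scatter) as steps that stay within the scatter. Only compound 2 stands apart from compound 4, so the ring keeps the level of compound 1 and compound 3 without improving on it. Nothing at hand explains this result.

From the compounds shown here alone, whether a piperidin-4-yl group, or a pyrrolidin-3-yl carrying a methyl on its nitrogen, holds this level remains open. A hydroxymethyl group on the same carbon would show whether an amine is needed at all.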